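The source may report more compounds than this note shows. Statements on the series, on what has been measured and on what is new or still open speak of the compounds shown alone.

The series shares one core and is varied at the amide chain. Compound 3 `CCCCCCCCCCCCCCCCNC(=O)[C@@H]1CSC(c2cc(OC)c(OC)c(OC)c2)N1` carries the longest chain; in a functional assay on cells (Homo sapiens) for antiproliferative activity, read by sulforhodamine B assay, with a stated time of 48 h (a higher number here means a weaker inhibitor, a lower number a stronger inhibitor), compound 3 gives 1800 nM. Compound 2 `CCCCCCCCCCCCNC(=O)[C@@H]1CSC(c2cc(OC)c(OC)c(OC)c2)N1` gives 2100 nM in this assay, and compound 1 `CCCCCCCCNC(=O)[C@@H]1CSC(c2cc(OC)c(OC)c(OC)c2)N1` gives 17100 nM in this assay. Among the three numbers compound 3 has the lowest, with compound 2 within the scatter of it and compound 1 beyond it. The chain steps run an 8.1-fold lower number from compound 1 to compound 2 (0.91 log units; beyond the scatter) and a 9.5-fold lower number from compound 1 to compound 3 (0.98 log units; beyond the scatter), whereas a 1.2-fold lower number from compound 2 to compound 3 (0.07 log units; within the scatter), so lengthening past compound 2 no longer moves the number.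

Compound 4 `CCCCCCCCCCCCCCCCNC(=O)[C@@H]1CSC(c2ccc(N)cc2)N1` keeps the chain of compound 3 and changes the group on the saturated ring carbon: 4-aminophenyl in place of 3,4,5-trimethoxyphenyl on a saturated ring carbon. Going by the values given here, none of the measured steps touches this position; all three concern the chain alone and give no direct guide to the size or direction of this change. The only inference is that the chain of compound 3 is not the limiting part, so any movement in compound 4 should come from the swap itself, and the expectation is therefore wide. The number for compound 4 in this assay is expected to rise, a 5.0-fold higher number from compound 3 to compound 4 (0.70 log units; beyond the scatter), to an estimated 9000 nM with a range from 2000 nM to 40000 nM.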

Compound 4, half-maximal inhibitory concentration: 2300 nM
Beside the measured number, compound 4's estimate is 3.9-fold (0.59 log units) above it; measured number inside the range.
By their numbers in this assay, from the lowest: compounds 3, 2 and 4 (each within the scatter of the next); then compound 1.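

On the saturated ring carbon, with the chain of compound 3 held fixed, 4-aminophenyl in place of 3,4,5-trimethoxyphenyl leaves the read-out in this assay unmoved beyond the scatter (a 1.3-fold higher number from compound 3 to compound 4 (0.11 log units; within the scatter)), which makes this the first sign that the position tolerates a change of aryl group. The entering group has fewer heavy atoms than the leaving group, and it has a hydrogen-bond donor where the leaving group has none, so for this pair neither the three methoxy groups nor that larger size is required to keep the number level. No measurement at hand accounts for how close the two aryl groups lie.

Going by these compounds alone, whether the swap behaves the same way on the shorter chains of compound 1 and compound 2 stays open, as the only pair that reads this position carries the chain of compound 3. Also open, on these data alone, is whether other groups on this carbon, such as plain phenyl, 4-hydroxyphenyl, 4-nitrophenyl or 4-dimethylaminophenyl, would stay level with compound 3 and compound 4.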